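The source may report more compounds than this note shows. Statements on the series, on what has been measured and on what is new or still open speak of the compounds shown alone.

Series notes. Compound 1 `COc1ccc(F)cc1CNCCCNc1ccnc2cc(Cc3ccc(C#N)cc3)ccc12` and compound 2 `COc1cccc(CNCCCNc2ccnc3cc(Cc4cccc(C(F)(F)F)c4)ccc23)c1O` have both been run in a physicochemical assay for acid dissociation. In this assay compound 1 gives 9.47. In this assay compound 2 gives 9.47, so compound 1 stands level with compound 2 at the digits shown, the two values lying within the scatter of one another. Compound 3 `COc1ccc(F)cc1CNCCCNc1ccnc2cc(Cc3ccc(F)cc3)ccc12` has not yet been run in this assay. It differs from compound 1 in one place: fluoro in place of cyano on an aromatic carbon. Among the compounds with values here, no step between measured compounds is available for this change. The expected step, no change at the digits printed from compound 1 to compound 3 (within the scatter), is none beyond the scatter, in no particular direction. Compound 3 is accordingly estimated at 9.47, with a range from 9.17 to 9.77.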

Compound 3, acid dissociation constant: 9.47
Compound 3: the middle estimate sits on the measured number at the digits printed, and the stated range covers the measured number.
By their numbers in this assay, from the lowest: compounds 1, 2 and 3 (each within the scatter of the next).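

In this assay, within the data shown here, fluoro in place of cyano on this aromatic carbon gives no change at the digits printed from compound 1 to compound 3 (within the scatter), the only step read so far at this position. The 4-cyanobenzyl and 4-fluorobenzyl forms therefore cannot be told apart by this read-out, a finding limited to this one pair. No measurement offered here accounts for this result.

On these data alone, whether an amine or a carboxylic acid on this same aromatic carbon would give a step beyond the scatter stays open. So does whether fluoro in place of cyano reads the same once the rest of compound 1 carries other groups.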